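The compounds below may be only part of what the source reports. "The series", "measured", "known", "first", "only" and "open" are said of these compounds alone.

In a functional assay on HT-29 cells (Homo sapiens) for cytotoxicity, read by MTT assay, with a stated time of 72 h (on this read-out lower numbers stand for stronger inhibition and higher numbers for weaker inhibition), compound 1 `Cc1ccc(NC(=O)CN2CCN(c3nnc(Cc4ccncc4)c4ccccc34)CC2)c(C)c1` gives 1930 nM as the lowest of the three numbers measured. Compound 2 `Cc1ccc(F)cc1NC(=O)CN1CCN(c2nnc(Cc3ccccc3)c3ccccc23)CC1` gives 171000 nM and compound 3 `COc1ccc(NC(=O)CN2CCN(c3nnc(Cc4ccccc4)c4ccccc34)CC2)cc1OC` gives 145000 nM as far higher numbers. Compound 4 `O=C(CN1CCN(c2nnc(Cc3ccncc3)c3ccccc23)CC1)Nc1c(F)cccc1F` keeps the core of compound 1 and differs in one place by 2,6-difluorophenyl in place of 2,4-dimethylphenyl on an amide-type nitrogen which amounts to 2,6-difluorophenyl in place of 2,4-dimethylphenyl on an amide-type nitrogen. Going by the values given here, the only measured step with a swap at that place alone is a 1.2-fold lower number from compound 2 to compound 3 (0.07 log units; within the scatter) and it stays within the scatter, so no step beyond the scatter is expected in this assay for this change, although one step is thin support. Compound 4 is estimated at 2500 nM with 600 nM to 12000 nM as the expected range. That expected a 1.3-fold higher number from compound 1 to compound 4 (0.11 log units; within the scatter) remains an estimate only.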

Compound 4, half-maximal inhibitory concentration: 28700 nM
Beside the measured number, compound 4's estimate is 11-fold (1.06 log units) below it, outside the stated range (above it).
By their numbers in this assay, from the lowest: compound 1; then compound 4; then compounds 3 and 2 (each within the scatter of the next).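

In this assay, a swap at this amide-type nitrogen now gives a large change, a 15-fold higher number from compound 1 to compound 4 (1.17 log units; beyond the scatter), whereas a 1.2-fold lower number from compound 2 to compound 3 (0.07 log units; within the scatter) had stayed within the scatter. The place is therefore not indifferent to the group it carries, even though 2,4-dimethylphenyl and 2,6-difluorophenyl both have 8 heavy atoms and one six-membered aromatic ring of carbon only. Nothing measured here explains this step. The compounds shown leave open whether the step follows the fluorine atoms or where they sit, and a 2,4-difluorophenyl group on the core of compound 1 would separate the two.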